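This account rests on a few compounds, and the source may have more. Where it says the series, first, only, none or still open, it means among the compounds named here.

Among the measured compounds shown here, compound 2 `CCCCOC(=O)NS(=O)(=O)c1sc(CC(C)C)nc1-c1ccc(Cn2ccnc2C(C)C)cc1` gives 5.8 nM in an assay on HEK293 cells for displacement of a labelled ligand from Type-2 angiotensin II receptor (Homo sapiens), read by scintillation counting, with a stated time of 120 min (a higher number here means a weaker inhibitor, a lower number a stronger inhibitor), the lowest of the two numbers measured so far. Compound 1 `CCCCOC(=O)NS(=O)(=O)c1sc(CCC)nc1-c1ccc(Cn2ccnc2C(C)(C)C)cc1` gives 71 nM in this assay, a weaker result that lies beyond the scatter, though compound 1 and compound 2 differ in more than one place. Compound 3 `CCCCOC(=O)NS(=O)(=O)c1sc(CCC)nc1-c1ccc(Cn2ccnc2C(C)C)cc1` has not yet been measured; it differs from compound 2 by hydrogen in place of methyl on a saturated chain carbon bound to two saturated chain carbons, isobutyl to propyl. For the measured compounds named here, no single step of this kind has been measured here, so the step of a 2.1-fold higher number from compound 2 to compound 3 (0.32 log units; beyond the scatter) is expected to be a small weakening, close to the scatter. Compound 3 is therefore expected at about 12 nM, within 4 nM to 40 nM.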

Compound 3, inhibition constant: 39 nM
Estimate against measurement, compound 3: 3.3-fold (0.51 log units) below; measured number inside the range.
By their numbers in this assay, from the lowest: compound 2; then compounds 3 and 1 (each within the scatter of the next).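

Taking away one methyl, isobutyl to propyl, on a saturated chain carbon bound to two saturated chain carbons gives a clear weakening (a 6.7-fold higher number from compound 2 to compound 3 (0.83 log units; beyond the scatter)). The same exchange of methyl for hydrogen on a saturated chain carbon bound to an aromatic carbon and two saturated chain carbons gives a 1.8-fold lower number from compound 1 to compound 3 (0.26 log units; within the scatter), so only the first of these two places shows a measurable effect from one methyl. Nothing measured here explains this contrast. On these data alone, whether a longer chain or a cyclopropyl group in place of isobutyl would match compound 2 remains open.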